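Isomeric anilide side chains on a bromomaleimide indole series

A few compounds are considered here, and "the series" means these few. Any claim that something is new, unique, unknown or untested is made for them only; others in the source may bear on it.

Measured compounds:
compound 1, `CCCCc1cccc2c(C3=C(Br)C(=O)NC3=O)c(-c3ccc(OC)cc3)[nH]c12`, 3.81;
compound 2, `CCCCOc1ccc2[nH]c(-c3cccc(OC)c3)c(C3=C(Br)C(=O)NC3=O)c2c1`, 3.46;
compound 3, `O=C(CCCCc1[nH]c2ccccc2c1C1=C(Br)C(=O)NC1=O)Nc1ccccc1`, 2.56.

In a physicochemical assay for lipophilicity (on this read-out higher numbers stand for higher lipophilicity and lower numbers for lower lipophilicity), compound 3 stands lowest of the three numbers; the nearest is compound 2, and the furthest is compound 1, both beyond the scatter. Compound 4, `Cc1ccccc1NC(=O)CCCc1[nH]c2ccccc2c1C1=C(Br)C(=O)NC1=O`, is not yet measured. It differs from compound 3 in one place: (2-methylphenyl)carbamoyl in place of (phenylcarbamoyl)methyl on a saturated chain carbon, three bonds along the chain from an aromatic carbon. The two share the same atoms, joined differently.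

Within the data shown here, compound 4 is expected to sit close to compound 3 in this assay, with a step of a number 0.09 log units higher from compound 3 to compound 4 (within the scatter) that is estimated to fall within the scatter and in no clear direction, as no pair of measured compounds shows a rearrangement of this kind to lean on. For compound 4 the estimate in this assay is 2.65, with a range from 2.25 to 3.05.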

Compound 4, partition coefficient: 2.56
Compound 4: the middle estimate sits 0.09 log units above what was measured; low and high end bracket the measured number.
By their numbers in this assay, from the lowest: compounds 3 and 4 (each within the scatter of the next); then compound 2; then compound 1.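

Putting (2-methylphenyl)carbamoyl in place of (phenylcarbamoyl)methyl on a saturated chain carbon, three bonds along the chain from an aromatic carbon, gives no change at the digits printed from compound 3 to compound 4 (within the scatter) in this assay. This is the only pair shown that differs in one place, and it shows that at this position the same atoms can be joined differently with the read-out staying within the scatter. Nothing measured here bears on why the two isomers match.

Among these compounds, one pair cannot show whether this holds for other chains and aryl groups, and no step to compound 1 or compound 2 can be read. Still open, as far as these compounds go, is how this assay responds at this position when a carboxylic acid or an amine replaces the anilide, or when a longer chain carries it.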